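The source may hold more compounds than are shown below. What is called first, only, known or untested is meant among the compounds shown, and "the series" means these compounds.

Measured so far:
compound 1 `CN1CCN(CC(=O)Nc2ccc(-c3nc4cc(Cl)c(Cl)cc4[nH]3)cc2)CC1`: 41000 nM
compound 2 `O=C(O)CCC(=O)Nc1ccc(-c2nc3cc(C(F)(F)F)ccc3[nH]2)cc1`: > 100000 nM

Both compounds were tested in an ADME assay on BHK cells (Mesocricetus auratus) for cytotoxicity, read by MTT assay, with a stated time of 96 h; on this read-out lower numbers stand for higher toxicity in this test and higher numbers for lower toxicity in this test. In this assay, among the measured compounds shown here, compound 1 gives 41000 nM, which is the only plain number in this small set. Compound 2 is reported only as a limit, > 100000 nM, so no exact number is known for it. Compound 2 thus sits at the limit of > 100000 nM in this assay, at which 1 of the 2 values shown sits. Compound 1 therefore stands alone as the one compound with a measured number, and no order between the two compounds can be stated from what is shown.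

Compound 3 `O=C(CN1CCCCC1)Nc1ccc(-c2nc3cc(Cl)c(Cl)cc3[nH]2)cc1` has not yet been tested. It differs from compound 1 in one place: piperidin-1-yl in place of 4-methylpiperazin-1-yl on a saturated chain carbon bound to a carbonyl carbon. For the measured compounds named here, no step between two measured compounds of this kind is available here, so the size of the change cannot be read from a precedent. In this assay a small step is expected, a 1.4-fold lower number from compound 1 to compound 3 (0.14 log units; within the scatter), not beyond the usual scatter of the test. Compound 3 is expected to give about 30000 nM in this assay, within a range from 12000 nM to 80000 nM.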

Compound 3, half-maximal cytotoxic concentration: 39000 nM
Estimate against measurement, compound 3: 1.3-fold (0.11 log units) below; the measured number falls inside the stated range.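

In this assay, among the compounds shown here, replacing 4-methylpiperazin-1-yl with piperidin-1-yl gives a 1.1-fold lower number from compound 1 to compound 3 (0.02 log units; within the scatter), and this is the first step in the set between two measured compounds that differ in one place. At this place, on a saturated chain carbon bound to a carbonyl carbon, going from a ring with 2 hetero atoms and 7 heavy atoms to a ring with 1 hetero atom and 6 heavy atoms therefore leaves the read-out within the usual scatter of the test. Nothing among the measurements shown offers a reason for this result.

This single pair cannot say whether a morpholin-4-yl ring, a dimethylamino group or a longer chain carrying the piperidin-1-yl ring would also stay within the scatter at this place. For the compounds shown here, it also leaves open whether the same exchange would read the same way on a core other than the one shared by compound 1 and compound 3.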